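From chloro to trifluoromethyl on the aromatic ring

The source may report more compounds than this note shows. Statements on the series, on what has been measured and on what is new or still open speak of the compounds shown alone.

In an ADME assay on GES1 cells (Homo sapiens) for inhibition, read by MTT assay, with a stated time of 72 h (a higher number here means a weaker inhibitor, a lower number a stronger inhibitor), compound 3 `Cc1cc(Nc2cc(-c3ccccc3)[nH]n2)n2nc(SCc3ccc(Cl)cc3)nc2n1` gives 31800 nM. Among the measured compounds shown here, the only other number comes from compound 1 `Cc1cc(Nc2cc(-c3ccccc3)[nH]n2)n2nc(SCc3ccc([N+](=O)[O-])cc3)nc2n1`, at 43600 nM, and the two values lie within the scatter of each other. Compound 2 `Cc1cc(Nc2cc(-c3ccccc3)[nH]n2)n2nc(SCC3CCCCC3)nc2n1` is reported only as a limit, > 50000 nM.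

Compound 4 `Cc1cc(Nc2cc(-c3ccccc3)[nH]n2)n2nc(SCc3ccc(C(F)(F)F)cc3)nc2n1` has trifluoromethyl in place of chloro on an aromatic carbon, para to a large group: trifluoromethyl in place of chloro on an aromatic carbon. The measured change at this same place is a 1.4-fold lower number from compound 1 to compound 3 (0.14 log units; within the scatter), with chloro in place of nitro, and it stays within the scatter. The two steps involving cyclohexyl, an at least 1.1-fold higher number from compound 1 to compound 2 (0.05 log units; that floor lies within the scatter) and an at least 1.5-fold lower number from compound 2 to compound 3 (0.19 log units; that floor lies within the scatter), have floors that also lie within the scatter. No step beyond the scatter is therefore expected in this assay. The estimated change is a 1.1-fold lower number from compound 3 to compound 4 (0.03 log units; within the scatter), which is too small to separate the two compounds. For compound 4 the expected value is 30000 nM, with an estimated range from 16000 nM to 50000 nM.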

Compound 4, half-maximal inhibitory concentration: 42700 nM
Compound 4: middle estimate off by 1.4-fold (0.15 log units), on the low side; measured number inside the range.
By their numbers in this assay, from the lowest: compounds 3, 4 and 1 (each within the scatter of the next). At a limit, above all of these: compound 2.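

Trifluoromethyl in place of chloro gives a 1.3-fold higher number from compound 3 to compound 4 (0.13 log units; within the scatter), and trifluoromethyl in place of nitro gives a 1.0-fold lower number from compound 1 to compound 4 (0.01 log units; within the scatter), so in this assay nitro, chloro and trifluoromethyl on this aromatic carbon cannot be told apart, even though trifluoromethyl brings four heavy atoms where chloro has one. Against cyclohexyl, the 4-(trifluoromethyl)phenyl group gives an at least 1.1-fold lower number from compound 2 to compound 4 (0.06 log units; that floor lies within the scatter), which again does not separate the two compounds. Compound 2 stands only as a limit: the limit of > 50000 nM in this assay, at which 1 of the 4 values shown sits.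

Going by these compounds, it remains open whether an amine or a carboxylic acid on this aromatic carbon would move the number beyond the scatter. The same holds for a longer chain on the sulfur, as no step shown so far at either place lies beyond it.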